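Cyano on the phenyl ring of an A3 receptor ligand

This account rests on a few compounds, and the source may have more. Where it says the series, first, only, none or still open, it means among the compounds named here.

Compound 1, with the structure `COc1cccc2cc(C(=O)Nc3c(C#N)ncn3-c3ccccc3)c(=N)oc12`, was tested in an assay on HeLa cells for displacement of a labelled ligand from adenosine receptor A3 (Homo sapiens), read by scintillation counting, with a stated time of 180 min, tested at 10 uM (on this read-out higher numbers stand for more inhibition at the one concentration tested (going by the name of the read-out) and lower numbers for less inhibition), where compound 1 gives 40%. A smaller relative, compound 2, with the structure `O=C(O)CNC(=O)c1cc2ccccc2oc1=O`, was tested alongside it; in this assay compound 2 gives 0%. Of these two numbers, compound 1 holds the higher one, and the gap to compound 2 lies beyond the usual scatter. Compound 3, with the structure `COc1cccc2cc(C(=O)Nc3c(C#N)ncn3-c3ccc(C#N)cc3)c(=N)oc12`, has not yet been measured. It differs from compound 1 in one place: cyano in place of hydrogen on an aromatic carbon. Within the data shown here, no pair of measured compounds shows what such an exchange does, so there is no measured step to lean on. The change is expected to leave the result near that of compound 1, with a step from no change at the digits printed from compound 1 to compound 3 (within the scatter) that is not expected to exceed the scatter. Compound 3 is therefore estimated at 40%, within a range from 15% to 65%.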

Compound 3, a percentage reported as inhibition, at one concentration (the size of the read-out at that concentration, not a potency): 1%
The estimate for compound 3 lay 39 percentage points above the measured number, and the stated range ends above it.
By their numbers in this assay, from the lowest: compounds 2 and 3 (each within the scatter of the next); then compound 1.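

Exchanging phenyl for 4-cyanophenyl is the only single-place change shown for this series, and in this assay it brings a large loss of inhibition at the one concentration tested (a number 39 percentage points lower from compound 1 to compound 3 (beyond the scatter)). This position, para to a large group, is therefore sensitive: adding a cyano group of just 2 heavy atoms in place of hydrogen is enough to remove nearly all of the signal seen with compound 1. No measurement here explains why the signal falls, so the reason remains unknown.

The compounds shown cannot tell whether this loss is specific to cyano or would also follow from another group at this carbon, such as a fluorine atom, an amine or a carboxylic acid. As far as these compounds go, it also remains open whether cyano on a different carbon of the same ring would have as large an effect.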